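A Thiophene in Place of the Hydroxyethyl Chain

This account rests on a few compounds, and the source may have more. Where it says the series, first, only, none or still open, it means among the compounds named here.

Compound 1 `Cc1nc(CCO)cc2nn(-c3ccccc3)cc12` is tested in a functional assay on K562 cells (Homo sapiens) for inhibition, read by fluorescence, with a stated time of 72 h (a lower number here means a stronger inhibitor of growth, a higher number a weaker inhibitor of growth), where compound 1 gives > 100000 nM, a limit of the assay rather than a number. Compound 2 `OCCc1cc2nn(-c3ccccc3)cc2cn1` also stops at a limit, giving > 100000 nM. The step that the two limits leave unreadable from compound 1 to compound 2 is therefore not readable, both values sitting at the limit of > 100000 nM in this assay, at which 2 of the 2 values shown sit. Compound 3 `Cc1nc(-c2ccsc2)cc2nn(-c3ccccc3)cc12` differs from compound 1 by thiophen-3-yl in place of 2-hydroxyethyl on an aromatic carbon. No measured step bears on this change, and the only step shown is unreadable, so the expected step of an at least 1.6-fold lower number from compound 1 to compound 3 (0.22 log units; that floor lies within the scatter) is estimated with little confidence in either direction. Compound 3 is expected to give about 60000 nM, within 3000 nM to 300000 nM.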

Compound 3, concentration for 50% growth inhibition: 10000 nM
Compound 3: middle estimate off by 6.0-fold (0.78 log units), on the high side; the range from low to high includes it.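

Thiophen-3-yl in place of 2-hydroxyethyl gives an at least 10-fold lower number from compound 1 to compound 3 (1.00 log units; beyond the scatter) in this assay, the only step shown that can be read. This position on the shared core, next to the ring nitrogen, can therefore carry a change that brings a value off the limit, which neither earlier compound showed: the limit of > 100000 nM in this assay, at which 2 of the 3 values shown sit.

What the compounds shown leave open is whether the aromatic ring or the loss of the chain accounts for the step, and how a phenyl ring, an amine or a longer chain would read here. Going by these compounds alone, the role of the methyl group also stays open, since the one step that changes it cannot be read.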